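From Chloro to Methoxy on an Aromatic Carbon

The compounds below may be only part of what the source reports. "The series", "measured", "known", "first", "only" and "open" are said of these compounds alone.

Compound 1 `Nc1ncc(-c2cccc(F)c2)c(-c2ccccc2)n1` gives 63% in an assay on CHO cells for displacement of a labelled ligand from adenosine receptor A1 (Homo sapiens), read by scintillation counting, with a stated time of 1 h, tested at 1 uM; a higher number here means more inhibition at the concentration tested (going by the name of the read-out), a lower number less inhibition.
Compound 2 `Nc1ncc(-c2cccc(Cl)c2)c(-c2ccccc2)n1` gives > 80% in this assay.

Compound 2 stands at a limit of this assay rather than at a number: the limit of > 80% in this assay, at which 1 of the 2 values shown sits. For the measured compounds named here, the one measured step, a number at least 17 percentage points higher from compound 1 to compound 2 (beyond the scatter), exchanges fluoro for chloro on an aromatic carbon. Compound 3 `COc1cccc(-c2cnc(N)nc2-c2ccccc2)c1` differs from compound 2 by methoxy in place of chloro on an aromatic carbon. Going by the values given here, no measured step exchanges chloro for methoxy, so the direction of this step is open. Compound 3 is expected to give about 60%, between 35% and 85%. That estimate means an expected step of a number at least 20 percentage points lower from compound 2 to compound 3 (beyond the scatter).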

Compound 3, a percentage reported as inhibition, at one concentration (the size of the read-out at that concentration, not a potency): > 80%
Compound 3: a limit, no number (the forecaster's own chance of this, stated with the estimate: 25%); at least 20 percentage points between middle value and limit.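

In this assay compound 3 gives > 80%, which is a limit and not a number. Methoxy in place of fluoro gives a number at least 17 percentage points higher from compound 1 to compound 3 (beyond the scatter), so at this aromatic carbon, chloro is no longer the only group that exceeds fluoro. Compound 2 and compound 3 share the same limit, so the step between them cannot be read: the limit of > 80% in this assay, at which 2 of the 3 values shown sit.

As far as these compounds go, the order of chloro and methoxy therefore stays open. So does whether an amine, a carboxylic acid or a longer chain on this aromatic carbon would also reach the limit.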